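The source may hold more compounds than are shown below. What is called first, only, known or untested is meant among the compounds shown, and "the series" means these compounds.

Measured so far:
- compound 1 `N#Cc1ccccc1CN1CCc2c(sc(NC(=O)c3ccccc3Cl)c2C(N)=O)C1` gives > 50000 nM in a functional assay on HeLa cells (Homo sapiens) for antiproliferative activity, with a stated time of 24 h; on this read-out higher numbers stand for weaker inhibition and lower numbers for stronger inhibition
- compound 2 `NC(=O)c1c(NC(=O)c2cccc([N+](=O)[O-])c2)sc2c1CCN(Cc1c(Cl)cccc1Cl)C2` gives 46100 nM in this assay

The value for compound 1 is a limit of the assay, not a number. Within the data shown here, compound 1 therefore stands at the limit of > 50000 nM in this assay, at which 1 of the 2 values shown sits; no step between compound 1 and compound 2 is worked out here, and their two values show only that both sit at the weak end of the read-out.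

Compound 3 `Cc1ccccc1NC(=S)N1CCc2c(sc(NC(=O)c3ccccc3Cl)c2C(N)=O)C1` is not yet measured. It differs from compound 1 by a group of 10 heavy atoms (8 carbon, 1 nitrogen, 1 sulfur; one six-membered aromatic ring of carbon only) in place of a group of 9 heavy atoms (8 carbon, 1 nitrogen; one six-membered aromatic ring of carbon only), on an amine nitrogen in a ring. The group that leaves carries a nitrile on its aromatic ring, while the group that enters holds a thiocarbonyl and an additional hydrogen-bond donor on the amine nitrogen of the six-membered non-aromatic ring.

With compound 1 at a limit, a step in this assay from compound 1 to compound 3 can only be estimated loosely; no change beyond the usual scatter is expected, and the estimated step of an at least 1.1-fold lower number from compound 1 to compound 3 (0.04 log units; that floor lies within the scatter) is small. Compound 3 is expected to give about 45000 nM, with a range from 15000 nM to 150000 nM.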

Compound 3, half-maximal inhibitory concentration: > 50000 nM
Compound 3: only a limit was reported; the forecaster's own chance of this, stated with the estimate: 55%; at least 1.1-fold (0.04 log units) between middle value and limit.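

Compound 3 gives > 50000 nM in this assay and this value is a limit of the assay, not a number. Among these compounds, compound 1 also stands at a limit, and no step from compound 1 to compound 3 can be read. The compounds shown leave open whether exchanging the 2-cyanobenzyl group on the amine nitrogen changes antiproliferative activity at all.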